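Compound 3: amino in place of methoxy

The compounds below may be only part of what the source reports. "The series", "measured", "known", "first", "only" and "open" are said of these compounds alone.

Measured so far in a functional assay on HEL cells (Homo sapiens); a lower number here means that less compound is tolerated, a higher number that more compound is tolerated:
Compound 1 `Cc1cn([C@@H]2O[C@H](CO[Si](C)(C)C(C)(C)C)[C@@]3(OS(=O)(=O)C=C3NCC(=O)O)[C@H]2O[Si](C)(C)C(C)(C)C)c(=O)n(C)c1=O`: 136000 nM
Compound 2 `COC(=O)C(=O)CNC1=CS(=O)(=O)O[C@@]12[C@@H](CO[Si](C)(C)C(C)(C)C)O[C@@H](n1cc(C)c(=O)n(C)c1=O)[C@@H]2O[Si](C)(C)C(C)(C)C`: > 200000 nM
Not yet measured: compound 3 `Cc1cn([C@@H]2O[C@H](CO[Si](C)(C)C(C)(C)C)[C@@]3(OS(=O)(=O)C=C3NCC(=O)C(N)=O)[C@H]2O[Si](C)(C)C(C)(C)C)c(=O)n(C)c1=O`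

In this assay compound 2 gives > 200000 nM, which is a limit of the assay and not a number. The data therefore hold one firm value alongside (the limit of > 200000 nM in this assay, at which 1 of the 2 values shown sits).

The step to compound 3 is amino in place of methoxy on a carbonyl carbon. In words, amino takes the place of methoxy on a carbonyl carbon, so that methoxycarbonyl becomes carbamoyl.

For the measured compounds named here, only one measured step bears on this change, since it too alters a group on a carbonyl carbon: an at least 1.4-fold higher number from compound 1 to compound 2 (0.16 log units; that floor lies within the scatter). Going by the values given here, that step offers only a floor, and no measured step covers amino. No step beyond the scatter is therefore expected in this assay, and no direction is favoured. Among the compounds with values here, compound 1, at 136000 nM, is the only firm number on which this expectation can rest.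

The expected step is an at least 1.1-fold lower number from compound 2 to compound 3 (0.07 log units; that floor lies within the scatter). Compound 3 is estimated at 170000 nM, with an expected range from 90000 nM to 320000 nM.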

Compound 3, half-maximal cytotoxic concentration: 14500 nM
Compound 3: middle estimate off by 12-fold (1.07 log units), on the high side; measured number below the stated range.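

In this assay, for the compounds shown here, amino in place of methoxy on a carbonyl carbon gives an at least 13-fold lower number from compound 2 to compound 3 (1.13 log units; beyond the scatter), so the group at this place can move the number well beyond the scatter, which the one earlier step, with its floor inside the scatter, could not show. Compound 2 stands at a limit of the assay and not at a number, so this step is only a floor and its true size is unknown: the limit of > 200000 nM in this assay, at which 1 of the 3 values shown sits.

The firm comparison is a 9.4-fold lower number from compound 1 to compound 3 (0.97 log units; beyond the scatter), for carbamoyl in place of hydroxy on a carbonyl carbon, and it makes carbamoyl the end group of the three at which the least compound is tolerated in this assay.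

On these data alone, whether this belongs to amino alone, or would also appear with methylamino or dimethylamino on the same carbonyl carbon, remains open. So does the outcome with a longer chain in place of the (carbamoylcarbonyl)methyl group, and with the carbamoyl group kept while the carbonyl carbon it sits on is replaced by a simple methylene.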